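Swapping a Phenyl for a Pyridine in a Weak Inhibitor

A few compounds are considered here, and "the series" means these few. Any claim that something is new, unique, unknown or untested is made for them only; others in the source may bear on it.

Three measured compounds share one core and differ only at its edges. Compound 1 `COc1ccc(Nc2nc(Oc3cccc(NC(=O)C=C(C)C)c3)c3sccc3n2)cc1` carries a 4-methoxyphenyl on a nitrogen on an aromatic ring; in a functional assay on MCF7 cells (Homo sapiens) for inhibition, read by MTT assay, with a stated time of 72 h (a lower number here means a stronger inhibitor, a higher number a weaker inhibitor), compound 1 gives 46100 nM. Compound 2 `COc1cccc(Nc2nc(Oc3cccc(NC(=O)C=C(C)C)c3)c3sccc3n2)c1` carries a 3-methoxyphenyl there instead, and in this assay compound 2 gives 35800 nM. Compound 3 `CCC/C=C/C(=O)Nc1cccc(Oc2nc(Nc3cccc(OC)c3)nc3ccsc23)c1` keeps that group but changes the chain on the carbonyl carbon; in this assay compound 3 gives 5020 nM.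

Among the three numbers compound 2 has the second highest, nearest to compound 1 and furthest from compound 3. The step of a 1.3-fold lower number from compound 1 to compound 2 (0.11 log units; within the scatter) lies within the scatter, whereas a 7.1-fold lower number from compound 2 to compound 3 (0.85 log units; beyond the scatter) lies beyond it and counts as modest.

Compound 4 `COc1ccc(Nc2nc(Oc3cccc(NC(=O)C=C(C)C)c3)c3sccc3n2)cn1` differs from compound 2 by 6-methoxypyridin-3-yl in place of 3-methoxyphenyl on a nitrogen on an aromatic ring. For the measured compounds named here, the only measured step touching the same position is a 1.3-fold lower number from compound 1 to compound 2 (0.11 log units; within the scatter), which exchanged one methoxyphenyl for another and produced nothing beyond the scatter. Going by the values given here, no measured step puts a nitrogen into that ring, so there is nothing to point in either direction. The expected step is therefore a 1.0-fold lower number from compound 2 to compound 4 (0.01 log units; within the scatter), nothing beyond the scatter. Compound 4 is estimated at 35000 nM, with a range from 12000 nM to 100000 nM.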

Compound 4, half-maximal inhibitory concentration: > 100000 nM
Compound 4 gave a limit, no number (the forecaster's own chance of this, stated with the estimate: 15%); at least 2.8-fold (0.45 log units) between middle value and limit.
By their numbers in this assay, from the lowest: compound 3; then compounds 2 and 1 (each within the scatter of the next). At a limit, above all of these: compound 4.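

Compound 4 gives a limit and not a number in this assay: the limit of > 100000 nM in this assay, at which 1 of the 4 values shown sits. Even so, the limit is enough to place it: there is an at least 2.7-fold higher number from compound 2 to compound 4 (0.44 log units; beyond the scatter), and an at least 2.1-fold higher number from compound 1 to compound 4 (0.33 log units; beyond the scatter), so both steps lie beyond the scatter, whereas the exchange of one methoxyphenyl for another, a 1.3-fold lower number from compound 1 to compound 2 (0.11 log units; within the scatter), stayed within it. As far as these compounds go, this position on the nitrogen therefore does respond to change: 6-methoxypyridin-3-yl, which has the same count of heavy atoms as either methoxyphenyl but a ring nitrogen in place of a ring carbon, shifts the result towards a weaker inhibitor, by an amount whose true size remains unknown.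

The compounds shown leave open whether the ring nitrogen alone accounts for this shift, or whether other groups here, such as a plain phenyl or a pyridine carrying an amine in place of the methoxy, would behave the same way. They also cannot tell whether the same exchange would cost as much alongside the pent-1-en-1-yl chain of compound 3, which gives 5020 nM.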